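Removing the fluorine: does compound 3 keep its edge?

The source may report more compounds than this note shows. Statements on the series, on what has been measured and on what is new or still open speak of the compounds shown alone.

Three compounds share a core built on two fused rings with a furan-bearing amine on one side and a second amine on the other. Compound 1 `c1coc(CNc2nc(NCCCN3CCCC3)nc3ccccc23)c1` carries a pyrrolidine-tipped chain on that second amine, compound 2 `COc1ccc(Nc2nc(NCc3ccco3)c3cc(F)ccc3n2)cc1` a 4-methoxyphenyl group, and compound 3 `CCCCNc1nc(NCc2ccco2)c2cc(F)ccc2n1` a butyl chain. In a functional assay on DU-145 cells (Homo sapiens) for cytotoxicity, read by MTT assay, with a stated time of 2 days, tested at 10 uM (a lower number here means less inhibition, a higher number more inhibition at the concentration tested (going by the name of the read-out)), compound 1 gives 40.1%, compound 2 gives 55.4% and compound 3 gives 75.4%. For the measured compounds named here, compound 3 therefore stands highest of the three, and the one measured step, a number 20 percentage points higher from compound 2 to compound 3 (beyond the scatter), shows the gain when butyl replaces 4-methoxyphenyl.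

Compound 4 `CCCCNc1nc(NCc2ccco2)c2ccccc2n1` differs from compound 3 in one place: hydrogen in place of fluoro on an aromatic carbon. Going by the values given here, no measured step touches this position, so no direct precedent exists. Compound 1 also lacks the fluorine but differs in the amine as well, so its lower value cannot be assigned to the fluorine alone. A single small atom leaving an aromatic carbon is usually a minor change, so for compound 4 a step of a number 7.4 percentage points lower from compound 3 to compound 4 (within the scatter) is expected, within or near the scatter, leaning slightly down. The estimate for compound 4 is 68%, with a range from 50% to 85%.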

Compound 4, a percentage reported as inhibition, at one concentration (the size of the read-out at that concentration, not a potency): 89.9%
Estimate against measurement, compound 4: 21.9 percentage points below, and the stated range ends below it.
By their numbers in this assay, from the lowest: compound 1; then compound 2; then compound 3; then compound 4.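

In this assay, swapping fluoro for hydrogen on this aromatic carbon gives a number 14.5 percentage points higher from compound 3 to compound 4 (beyond the scatter), so with a butyl chain on the second amine, the fluorine is not needed for a high reading, and the compound without it reads higher. Removing the fluorine also creates a pair differing only at the chain end: methyl in place of pyrrolidin-1-yl gives a number 49.8 percentage points higher from compound 1 to compound 4 (beyond the scatter), a large step against the modest one at the aromatic carbon, which makes the chain end the more sensitive of these two places in this series. No measured evidence here explains either step.

As far as these compounds go, the fluoro-to-hydrogen comparison rests on a single pair with a butyl chain, so it remains open whether the same change would raise the reading with the 4-methoxyphenyl group of compound 2. Also open, from the compounds shown here alone, is how a chloro or methoxy group on that aromatic carbon, or a hexyl chain or morpholine tip on the second amine, would read at this single tested concentration.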